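Ethoxy in place of methylsulfanyl on the shared core

This account rests on a few compounds, and the source may have more. Where it says the series, first, only, none or still open, it means among the compounds named here.

Within the data shown here, compound 3 `CSc1ccnc(Nc2ccc(Cl)c(OCC=C(C)C)c2)n1` holds the second highest of the three numbers measured so far in an ADME assay on MT2 cells (Homo sapiens) for cytotoxicity; on this read-out lower numbers stand for higher toxicity in this test and higher numbers for lower toxicity in this test: compound 3 gives 2800 nM. Its nearest neighbour is compound 1 `COc1ccnc(Nc2ccc(Cl)c(OCC=C(C)C)c2)n1`, which in this assay gives 9000 nM, the step being a 3.2-fold lower number from compound 1 to compound 3 (0.51 log units; beyond the scatter). Furthest away is compound 2 `CC(C)=CCOc1cc(Nc2nccc(N)n2)ccc1Cl`, which in this assay gives 500 nM; the step is a 5.6-fold higher number from compound 2 to compound 3 (0.75 log units; beyond the scatter), and from the methoxy compound the step is an 18-fold lower number from compound 1 to compound 2 (1.26 log units; beyond the scatter).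

Compound 4 `CCOc1ccnc(Nc2ccc(Cl)c(OCC=C(C)C)c2)n1` has not been measured. The change from compound 3 is ethoxy in place of methylsulfanyl on an aromatic carbon.

Of the measured steps, a 3.2-fold lower number from compound 1 to compound 3 (0.51 log units; beyond the scatter) bears most directly: it swaps methoxy for methylsulfanyl at the same place and was modest. The steps involving amino, an 18-fold lower number from compound 1 to compound 2 (1.26 log units; beyond the scatter) and a 5.6-fold higher number from compound 2 to compound 3 (0.75 log units; beyond the scatter), were larger but concern a group absent here. Ethoxy is the closer relative of methoxy than of methylsulfanyl, so compound 4 is expected to sit between compound 3 and compound 1, giving a modest rise of a 1.8-fold higher number from compound 3 to compound 4 (0.25 log units; within the scatter). In this assay compound 4 is therefore estimated at 5000 nM, with a range from 2000 nM to 13000 nM.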

Compound 4, half-maximal cytotoxic concentration: 19000 nM
Compound 4: the middle estimate sits 3.8-fold (0.58 log units) below what was measured; measured number above the stated range.
By their numbers in this assay, from the lowest: compound 2; then compound 3; then compound 1; then compound 4.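

At this position, on an aromatic carbon next to the ring nitrogen, the oxygen-linked groups do not simply group together against methylsulfanyl: a 6.8-fold higher number from compound 3 to compound 4 (0.83 log units; beyond the scatter) in this assay takes the series past the methoxy compound. One added methyl on the saturated chain carbon bound to the oxygen is enough to matter here, since a 2.1-fold higher number from compound 1 to compound 4 (0.32 log units; beyond the scatter) is printed as beyond the scatter, so methoxy and ethoxy are not interchangeable in this test. With a 38-fold higher number from compound 2 to compound 4 (1.58 log units; beyond the scatter) as the widest gap among the four, the order at this place now runs amino, methylsulfanyl, methoxy, ethoxy, from the lowest number to the highest, and compound 4 stands highest, with its steps to all three others beyond the scatter.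

On these data alone, whether the number keeps rising with a longer chain such as propoxy, or with a branched isopropoxy, stays open, as does the standing of a dimethylamino group at this place relative to amino. No measured evidence is available to account for any of these steps.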